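Phenyl for Isopropyl: Solubility Expected to Hold Steady

The source may hold more compounds than are shown below. What is called first, only, known or untested is meant among the compounds shown, and "the series" means these compounds.

Three related compounds have been measured in a physicochemical assay for solubility, with a stated time of 18 h, at pH 7.4; a higher number here means a more soluble compound, a lower number a less soluble compound. Compound 1 `COc1ccc(F)cc1CNCCCNc1ccnc2cc(Cc3cc(C)cc(C)c3)ccc12` gives 4200 nM in this assay. Compound 2 `COc1ccc(F)cc1CNCCCNc1ccnc2cc(CCC(C)C)ccc12` gives 4200 nM, and compound 3 `COc1cccc(CNCCCNc2ccnc3cc(CCC(C)C)ccc23)c1O` gives 4200 nM. For the measured compounds named here, compound 2 therefore stands level with compound 1 and compound 3, and no pair among the three is separated by more than the usual scatter.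

The two measured steps tell the same story. The step of no change at the digits printed from compound 1 to compound 2 (within the scatter) came from putting isobutyl in place of 3,5-dimethylphenyl on a saturated chain carbon bound to an aromatic carbon. The step of no change at the digits printed from compound 2 to compound 3 (within the scatter) came from putting 2-hydroxy-3-methoxyphenyl in place of 5-fluoro-2-methoxyphenyl on a saturated chain carbon bound to an amine nitrogen.

Compound 4 `COc1ccc(F)cc1CNCCCNc1ccnc2cc(CCc3ccccc3)ccc12` has not yet been measured. It differs from compound 2 by phenyl in place of isopropyl on a saturated chain carbon, two bonds along the chain from an aromatic carbon. The step that bears most directly on this change is no change at the digits printed from compound 1 to compound 2 (within the scatter), which also exchanged an aromatic ring for a branched alkyl group on a saturated chain carbon bound to an aromatic carbon and moved nothing beyond the scatter. On that basis the expected step is no change at the digits printed from compound 2 to compound 4 (within the scatter), meaning no change beyond the scatter. Compound 4 is therefore estimated to give 4200 nM in this assay, with a range from 2000 nM to 8500 nM.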

Compound 4, solubility: 4200 nM
The estimate for compound 4 equals the measured number at the digits printed, within the range that was stated.
By their numbers in this assay, from the lowest: compounds 1, 2, 3 and 4 (each within the scatter of the next).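

For the compounds shown here, the step of no change at the digits printed from compound 2 to compound 4 (within the scatter) is the first reading in this assay for a change on a saturated chain carbon, two bonds along the chain from an aromatic carbon, and it shows that phenyl can take the place of isopropyl there without moving the value beyond the scatter. The earlier swap of a ring for an alkyl group sat one carbon closer to the core, so this result extends the same outcome to a second place on the chain, with an isopentyl chain and a phenethyl chain now reading alike. The step of no change at the digits printed from compound 1 to compound 4 (within the scatter) also stays within the scatter, and nothing available accounts for why these values stand level.

Every group at this place in the compounds shown is built of carbon alone, so they leave open how the value would respond to a chain ending in an amine or a carboxylic acid. A hydroxyl group or an amide on this chain would also be a separate question that these compounds cannot answer.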